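Pentyl for Isopentyloxy: Expectation for Compound 4

A few compounds are considered here, and "the series" means these few. Any claim that something is new, unique, unknown or untested is made for them only; others in the source may bear on it.

Three compounds of the series have been run in an assay on CHO cells for antagonist activity at transient receptor potential cation channel subfamily V member 1 (Homo sapiens), read by FLIPR; on this read-out higher numbers stand for weaker inhibition and lower numbers for stronger inhibition. Compound 1 `CC(C(=O)NCc1ccc(C(F)(F)F)cc1N1CCC(Cc2ccc(F)cc2)CC1)c1ccc(NS(C)(=O)=O)c(F)c1` gives 0.4 nM in this assay. Compound 2 `CC(C)CCOc1cc(C(F)(F)F)ccc1CNC(=O)C(C)c1ccc(NS(C)(=O)=O)c(F)c1` gives 0.5 nM in this assay, and compound 3 `C[C@H](C(=O)NCc1ccc(C(F)(F)F)cc1SC1CCCCC1)c1ccc(NS(C)(=O)=O)c(F)c1` gives 0.3 nM in this assay. The three numbers lie within the usual scatter of one another, so compound 2 cannot be set apart from compound 1 or compound 3 on these data; its value belongs to the same narrow cluster.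

Compound 4 `CCCCCc1cc(C(F)(F)F)ccc1CNC(=O)C(C)c1ccc(NS(C)(=O)=O)c(F)c1` has not yet been measured. It differs from compound 2 in one place: pentyl in place of isopentyloxy on an aromatic carbon. Among the measured compounds shown here, no measured pair differs in a single place, so there is no measured step that guides this change directly. What the data show is that the three measured compounds, carrying different groups at this part of the structure, all sit at the same level in this assay.

The step from compound 2 to compound 4 in this assay is therefore expected to be small, a 1.6-fold higher number from compound 2 to compound 4 (0.20 log units; within the scatter), with no direction beyond the scatter. Compound 4 is expected to give 0.8 nM in this assay, within a range of 0.3 nM to 2.5 nM.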

Compound 4, inhibition constant: 0.4 nM
For compound 4 the middle estimate is 2.0-fold (0.30 log units) above the measured one; the measured number falls inside the stated range.
By their numbers in this assay, from the lowest: compounds 3, 1, 4 and 2 (each within the scatter of the next).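

In this assay the series now has its first step that differs in one place, and pentyl in place of isopentyloxy on this aromatic carbon gives no change beyond the scatter (a 1.3-fold lower number from compound 2 to compound 4 (0.10 log units; within the scatter)). Among the compounds shown here, the oxygen, and with it the single hydrogen-bond acceptor of the isopentyloxy group, can therefore be absent from this position, ortho to a large group, without the number leaving the cluster of the earlier compounds. No measurement bears on why the step is this small.

The compounds shown leave open whether an amine or a carboxylic acid on this aromatic carbon would stay in the same cluster. They also leave open whether a chain as short as ethyl would hold the number at this level.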